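Thiophene Carboxamides with Two Amide Substituents: a Fourth Analogue

This account rests on a few compounds, and the source may have more. Where it says the series, first, only, none or still open, it means among the compounds named here.

Four compounds share a core whose pendant groups vary at two places. Compound 1 `NC(=O)c1c(NC(=O)c2ccc(C(F)(F)F)cc2)sc2c1CCN(Cc1c(Cl)cccc1Cl)C2`, compound 2 `NC(=O)c1c(NC(=O)c2ccccc2F)sc2c1CCN(Cc1c(Cl)cccc1Cl)C2` and compound 3 `NC(=O)c1c(NC(=O)c2ccccc2F)sc2c1CCN(C(=S)Nc1cc(C(F)(F)F)cc(C(F)(F)F)c1)C2` have been measured in a functional assay on MKN-74 cells (Homo sapiens) for antiproliferative activity, with a stated time of 24 h; on this read-out lower numbers stand for stronger inhibition and higher numbers for weaker inhibition. Compound 1 gives 8530 nM, compound 2 gives 7430 nM and compound 3 gives 13300 nM. Compounds 1 and 2 differ in one place, with 4-(trifluoromethyl)phenyl in place of 2-fluorophenyl on a carbonyl carbon, and this gave a 1.1-fold higher number from compound 2 to compound 1 (0.06 log units; within the scatter). The difference between the cores of compound 2 and compound 3 is not broken down here.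

Compound 4 `NC(=O)c1c(NC(=O)c2ccc(C(F)(F)F)cc2)sc2c1CCN(C(=S)Nc1cc(C(F)(F)F)cc(C(F)(F)F)c1)C2` has not yet been measured. It differs from compound 3 by 4-(trifluoromethyl)phenyl in place of 2-fluorophenyl on a carbonyl carbon, the same change that separates compound 2 from compound 1, occurring twice among these compounds. Because the earlier step of a 1.1-fold higher number from compound 2 to compound 1 (0.06 log units; within the scatter) sat within the scatter, compound 4 is expected to land close to compound 3, with an estimated step of a 1.1-fold higher number from compound 3 to compound 4 (0.04 log units; within the scatter). For compound 4 the expected value is 14500 nM, with an estimated range from 7000 nM to 30000 nM.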

Compound 4, half-maximal inhibitory concentration: 13800 nM
For compound 4 the middle estimate is 1.1-fold (0.02 log units) above the measured one, within the range that was stated.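

In this assay, within the data shown here, 4-(trifluoromethyl)phenyl in place of 2-fluorophenyl on a carbonyl carbon gave a 1.0-fold higher number from compound 3 to compound 4 (0.02 log units; within the scatter), so on this second core too the change produced no step that can be told from the scatter. Set beside the earlier case, the two steps agree: the same change on two cores in this assay, a 1.1-fold higher number (0.06 log units; within the scatter) from compound 2 to compound 1 and a 1.0-fold higher number (0.02 log units; within the scatter) from compound 3 to compound 4, 1.1-fold (0.04 log units) apart, within the scatter of two such steps. This shows that, on these two cores, the change was equally without a readable effect, but it does not show that a step of real size would carry from one core to another, and two cores say nothing about the rest of the series.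

The compounds shown leave open whether any other group on the carbonyl carbon, such as an aminophenyl ring or a longer alkyl chain, would move the read-out on either core. They also leave open how a carboxylic acid or an amine at the other varied place of the shared core would behave.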